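The compounds below may be only part of what the source reports. "The series", "measured", "known", "first", "only" and "open" are said of these compounds alone.

The measured compounds:
compound 1 `CCc1cccc(NC(=O)CN2CCN(c3ccccn3)CC2)c1`, 26.2%
compound 2 `Cc1cccc(NC(=O)CN2CCC(c3ccc(Cl)cc3)CC2)c1`, "not active" (no number reported)
compound 3 `O=C(CN1CCN(c2ccccn2)CC1)Nc1cncnc1`, "not active" (no number reported)

In an assay on cells for agonist activity at D(4) dopamine receptor (Homo sapiens), read by luminescence and beta-arrestin recruitment, with a stated time of 90 min (on this read-out lower numbers stand for smaller maximal responses and higher numbers for larger maximal responses), compound 3 gives "not active" (no number reported), so no single number stands for it, and compound 2 is a further entry of the same kind without a number. Compound 1, by contrast, gives 26.2% in this assay. The step considered here leads from compound 3 to compound 4 `Cc1cccc(NC(=O)CN2CCN(c3ccccn3)CC2)c1`, which has not yet been measured. The change is 3-methylphenyl in place of pyrimidin-5-yl on an amide-type nitrogen. Among the compounds with values here, no step between two measured compounds is available to set the size of this change, so the direction can only be judged from the single numbered entry. Compound 1 shows that the shared core of compound 3 and compound 4 can carry a measurable response. Because compound 1 reaches 26.2% while compound 3 gives no number, compound 4 is expected to move from no reported activity toward a small but measurable maximal response, estimated at 23% with a range of 5% to 40%.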

Compound 4, largest response reached (Emax), in percent of the reference or control that the assay uses: 30.7%
Compound 4: the middle estimate sits 7.7 percentage points below what was measured; the measured number falls inside the stated range.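

In this assay the amide-type nitrogen of the shared core now has a direct comparison: with 3-methylphenyl in place of pyrimidin-5-yl, compound 4 gives 30.7% while compound 3 gives "not active" (no number reported) in the same assay, so the group on this nitrogen decides whether a number is reported at all. Within the data shown here, the chain on the aromatic ring can also be read for the first time: the data show a number 4.5 percentage points higher from compound 1 to compound 4 (within the scatter) with hydrogen in place of methyl on a saturated chain carbon bound to an aromatic carbon, so the ethyl and methyl forms cannot be told apart here. Nothing available explains why the two groups on this nitrogen give different outcomes.

As far as these compounds go, whether a plain phenyl group, with no chain on the ring, would still give a number in this assay remains open. Equally open, from the compounds shown here alone, is what a propyl chain, a methoxy group or an amine on that ring would give.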